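Series notes: aryl swap on the hydrazone carbon, compound 3

The source may hold more compounds than are shown below. What is called first, only, known or untested is meant among the compounds shown, and "the series" means these compounds.

Two members of the shared core have been measured in a functional assay on the whole organism (strain Wistar) for inhibition, with Rattus norvegicus as the target, read by paw edema, with a stated time of 30 min, at a dose of 10 mg/kg by the intraperitoneal route; a higher number here means more inhibition at the dose given (going by the name of the read-out), a lower number less inhibition: compound 1 `O=C(N/N=C/c1ccccc1)c1cccnc1Nc1cccc(C(F)(F)F)c1` gives 60.4%, and compound 2 `O=C(N/N=C/c1cccc(O)c1)c1cccnc1Nc1cccc(C(F)(F)F)c1` gives 67.5%. Going by the values given here, the only step between them, a number 7.1 percentage points higher from compound 1 to compound 2 (within the scatter), lies within the scatter, so compound 2 is not separated from compound 1 beyond the scatter. Compound 3 `COc1ccc(/C=N/NC(=O)c2cccnc2Nc2cccc(C(F)(F)F)c2)c(OC)c1` differs from compound 2 by 2,4-dimethoxyphenyl in place of 3-hydroxyphenyl on a carbon with a double bond to nitrogen. Among the compounds with values here, no measured step bears on this change; the one known step, hydroxy for hydrogen, stayed within the scatter, so no step beyond the scatter is expected in this assay, the estimated step being a number 5.5 percentage points lower from compound 2 to compound 3 (within the scatter). Compound 3 is expected to give 62%, between 45% and 78%.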

Compound 3, a percentage reported as inhibition, in the whole organism at one dose (the size of the read-out at that dose, not a potency): 37.8%
Compound 3: middle estimate off by 24.2 percentage points, on the high side; measured number below the stated range.
By their numbers in this assay, from the lowest: compound 3; then compounds 1 and 2 (each within the scatter of the next).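

The aryl group on the carbon with a double bond to nitrogen is not a silent position in this assay: 2,4-dimethoxyphenyl in place of 3-hydroxyphenyl gives a number 29.7 percentage points lower from compound 2 to compound 3 (beyond the scatter) and in place of phenyl gives a number 22.6 percentage points lower from compound 1 to compound 3 (beyond the scatter) with both steps beyond the scatter. Going by these compounds alone, this is the first change here to pass the scatter, as the hydroxy step did not. Nothing available explains the fall. Open, as far as these compounds go, is whether the fall belongs to one methoxy group or to both, and how a phenyl carrying a single methoxy or an aminophenyl would behave at this place.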